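Compound 3 after a steep loss of growth inhibition

The compounds below may be only part of what the source reports. "The series", "measured", "known", "first", "only" and "open" are said of these compounds alone.

In a functional assay on RT-112 cells (Homo sapiens) for antiproliferative activity, read by MTT assay, with a stated time of 72 h (a higher number here means a weaker inhibitor of growth, a lower number a stronger inhibitor of growth), compound 1 `COc1cc(Nc2ncnc3c(NC(=O)Nc4cc(Cl)cc(Cl)c4)cccc23)cc(OC)c1` gives 30.2 nM. Compound 2 `COc1cc(Nc2ncnc3c(NC(=O)Nc4ccc(Cl)c(C(F)(F)F)c4)cccc23)cc(OC)c1` gives > 20000 nM, which is a limit of the assay and not a number. Going by these compounds, compound 2 therefore stands at the limit of > 20000 nM in this assay, at which 1 of the 2 values shown sits, and its true value remains unknown.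

Compound 3 `COc1cc(Nc2ncnc3c(NC(=O)Nc4ccc(F)cc4C(F)(F)F)cccc23)cc(OC)c1` differs from compound 2 in a single place: 4-fluoro-2-(trifluoromethyl)phenyl in place of 4-chloro-3-(trifluoromethyl)phenyl on an amide-type nitrogen. Here, 4-fluoro-2-(trifluoromethyl)phenyl replaces 4-chloro-3-(trifluoromethyl)phenyl on an amide-type nitrogen, whose other neighbour is the carbonyl carbon.

Going by the values given here, only one measured step bears on this place. The large step of an at least 660-fold higher number from compound 1 to compound 2 (2.82 log units; beyond the scatter), beyond the scatter, came with 4-chloro-3-(trifluoromethyl)phenyl in place of 3,5-dichlorophenyl on the same nitrogen. It shows that a change here can matter greatly, but it does not show how the entering group will behave. Compound 3 keeps a trifluoromethyl group, as does compound 2, so it is expected to stay toward the weak end of the range, with any shift going toward a lower number. The expected step, an at least 2.0-fold lower number from compound 2 to compound 3 (0.30 log units; that floor lies within the scatter), is small beside the measured one, and the assay may again report only a limit. For compound 3 the estimate is 10000 nM, with an expected range from 800 nM to 30000 nM.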

Compound 3, concentration for 50% growth inhibition: 2970 nM
Compound 3: middle estimate off by 3.4-fold (0.53 log units), on the high side; the measured number falls inside the stated range.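

In this assay the change to 4-fluoro-2-(trifluoromethyl)phenyl gives an at least 6.7-fold lower number from compound 2 to compound 3 (0.82 log units; beyond the scatter) and so shows that a phenyl group carrying trifluoromethyl on this amide-type nitrogen can keep measurable growth inhibition, which compound 2 alone could not show. The gain does not recover the level of compound 1, as the entering group still leaves a 98-fold higher number from compound 1 to compound 3 (1.99 log units; beyond the scatter) and 3,5-dichlorophenyl remains the better of the three groups shown at this place. Compound 2 gives a limit of the assay and not a number, so the true size of the step from it stays unknown: the limit of > 20000 nM in this assay, at which 1 of the 3 values shown sits.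

What remains open is which part of the change carries the gain, as 4-fluoro-2-(trifluoromethyl)phenyl differs from 4-chloro-3-(trifluoromethyl)phenyl both in its halogen and in where the trifluoromethyl group stands, and the compounds shown do not separate the two. Also open, going by these compounds, is how this nitrogen would take a group of another kind, such as a methoxy-bearing phenyl, a pyridine ring, or a plain alkyl chain in place of the halogen-bearing phenyl.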